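A few compounds are considered here, and "the series" means these few. Any claim that something is new, unique, unknown or untested is made for them only; others in the source may bear on it.

Compound 1 (`O=C(Nc1ccc(Cl)cc1)Nc1ccc(Nc2ncnc3c2OCCN3)cc1`), compound 2 (`O=C(Nc1ccc(Br)cc1)Nc1ccc(Nc2ncnc3c2OCCN3)cc1`) and compound 3 (`COc1cccc(NC(=O)Nc2ccc(Nc3ncnc4c3OCCN4)cc2)c1`) share one core and differ in the group on an amide-type nitrogen. In a functional assay on BaF3 cells (Mus musculus) for inhibition, read by MTT assay, with a stated time of 3 days (on this read-out higher numbers stand for weaker inhibition of growth and lower numbers for stronger inhibition of growth), compound 1 gives > 10000 nM as a limit of the assay and not a number. In this assay compound 2 gives 10000 nM as a true number. Compound 3 gives > 10000 nM which is again a limit and not a number. Compound 4 (`Cc1cc(C)cc(NC(=O)Nc2ccc(Nc3ncnc4c3OCCN4)cc2)c1`) carries 3,5-dimethylphenyl in place of 3-methoxyphenyl on an amide-type nitrogen. For the measured compounds named here, three steps bear on this change: a number no higher from compound 1 to compound 2 (the limit leaves the size open) then a step that the two limits leave unreadable from compound 1 to compound 3 and a number no lower from compound 2 to compound 3 (the limit leaves the size open) and none of them has a readable size. The measured set rests largely at the limit of > 10000 nM in this assay, at which 2 of the 3 values shown sit, and offers no clear movement. Going by the values given here, with compound 2 at 10000 nM as the only true number, no step beyond the scatter is expected in this assay in either direction. The expected change is a number no higher from compound 3 to compound 4 (the limit leaves the size open) and no more. The estimate for compound 4 is 10000 nM with 5000 nM to 20000 nM as the expected range.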

Compound 4, concentration for 50% growth inhibition: > 10000 nM
Compound 4 gave a limit, no number; the forecaster's own chance of this, stated with the estimate: 70%; the middle value lies on the limit itself.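

At this position on an amide-type nitrogen, 3,5-dimethylphenyl in place of 3-methoxyphenyl brings no readable change in this assay; the steps linking compound 4 to compound 1 and to compound 3 cannot be read, with a limit at both ends. For the compounds shown here, the only step with a direction is a number no lower from compound 2 to compound 4 (the limit leaves the size open), and its size stays open, so compound 2 remains the only compound here with a true number. A phenyl ring with two methyl groups and no oxygen thus joins the halogen and methoxy rings, and the set now rests even more heavily on one value: the limit of > 10000 nM in this assay, at which 3 of the 4 values shown sit.

What the compounds shown leave open is whether any group on this nitrogen gives a readable number well under that limit. A carboxylic acid or an amine on the ring, or a longer alkyl chain in place of the ring, could test this.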